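From methylcarbamoyl to thiophen-2-yl on compound 1

A few compounds are considered here, and "the series" means these few. Any claim that something is new, unique, unknown or untested is made for them only; others in the source may bear on it.

Compound 1 (`CNC(=O)CN1CCC(c2cc3c(-c4ccc(=O)n(C(C)C)c4)ccnc3[nH]2)CC1`) is the reference point for this step. In an ADME assay (Rattus norvegicus, strain Han-wistar) for pharmacokinetics, at a dose of 1.5 umol/kg by the intravenous route (on this read-out lower numbers stand for slow clearance and higher numbers for fast clearance), compound 1 gives 89 mL/min/kg. Alongside it, compound 2 (`CC(C)n1cc(-c2ccnc3[nH]c(C4CCN(CC(=O)N(C)C)CC4)cc23)cnc1=O`) gives 72 mL/min/kg. Going by the values given here, these two numbers lie within the usual scatter of repeated measurements, so compound 1 stands level with the only other measured compound, and neither can be ranked above the other.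

The next compound to be tested is compound 3 (`CC(C)n1cc(-c2ccnc3[nH]c(C4CCN(Cc5cccs5)CC4)cc23)ccc1=O`). It carries thiophen-2-yl in place of methylcarbamoyl on a saturated chain carbon bound to an amine nitrogen in a ring. Cut one bond further out, the same difference reads (methylcarbamoyl)methyl to (thiophen-2-yl)methyl.

Among the compounds with values here, no pair of measured compounds shows this change on its own, so nothing measured points firmly up or down. The expectation therefore stays anchored on compound 1 at 89 mL/min/kg, with a wide range to reflect how little is known. The estimated change is a 1.2-fold lower number from compound 1 to compound 3 (0.07 log units; within the scatter), which is expected to stay within the scatter in this assay. For compound 3 the estimated clearance is 75 mL/min/kg, with an expected range from 40 mL/min/kg to 125 mL/min/kg.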

Compound 3, clearance: 92 mL/min/kg
Estimate against measurement, compound 3: 1.2-fold (0.09 log units) below; measured number inside the range.
By their numbers in this assay, from the lowest: compounds 2, 1 and 3 (each within the scatter of the next).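

Going by these compounds alone, this is the first step read at this position: putting thiophen-2-yl in place of methylcarbamoyl on a saturated chain carbon bound to an amine nitrogen in a ring gives a 1.0-fold higher number from compound 1 to compound 3 (0.01 log units; within the scatter) in this assay and so leaves the two compounds level. The swap is not a small one, since a group without a ring, with a carbonyl and a hydrogen-bond donor, gives way to a five-membered aromatic ring with sulfur and no donor, yet this pair shows no separation in clearance, so at this position the read-out does not depend on keeping the methylcarbamoyl group. Nothing measured here explains why the two compounds stand level.

One pair cannot show whether this position is insensitive to every change, and a carboxylic acid, a primary amine or a longer alkyl chain in the same place could still give a clearance clearly apart from these. From the compounds shown here alone, it also remains open whether thiophen-2-yl would behave the same way on the core of compound 2, which differs from compound 1 in more than one place.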